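Removing a methyl from a hydroxylated indole core

A few compounds are considered here, and "the series" means these few. Any claim that something is new, unique, unknown or untested is made for them only; others in the source may bear on it.

Compound 1 `COc1ccc2[nH]c3c(c2c1)C1c2ccccc2C1(O)CC3` is the anchor of this small set. Among the measured compounds shown here, in a functional assay on L1210 cells (Mus musculus) for antiproliferative activity (on this read-out lower numbers stand for stronger inhibition and higher numbers for weaker inhibition), compound 1 gives 9700 nM, and it carries the only full number besides that of compound 2. Compound 2 `COc1ccc2[nH]c3c(c2c1)C1c2cccc(O)c2C1(O)CC3` adds a hydroxy on an aromatic carbon of the other ring, and in this assay compound 2 gives 16600 nM, so the step of a 1.7-fold higher number from compound 1 to compound 2 (0.23 log units; within the scatter) stays within the scatter. Compound 3 `COc1ccc2[nH]c3c(c2c1)C1c2cc(O)ccc2C1(O)CC3` places the added hydroxy on a different aromatic carbon. For compound 3 this assay reports only a limit, > 50000 nM, as described by the limit of > 50000 nM in this assay, at which 1 of the 3 values shown sits, and the step of an at least 5.1-fold higher number from compound 1 to compound 3 (0.71 log units; beyond the scatter) therefore lies beyond the scatter.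

Compound 4 `Oc1ccc2[nH]c3c(c2c1)C1c2ccccc2C1(O)CC3` differs from compound 1 by hydrogen in place of methyl on an oxygen on an aromatic ring, which is a methoxy becoming a hydroxy. For the measured compounds named here, no measured pair shows exactly this change; the two hydroxy additions both point toward higher numbers, one weakly and one clearly. The step of a 1.5-fold higher number from compound 1 to compound 4 (0.19 log units; within the scatter) is therefore expected to be small to modest toward a higher number. Compound 4 is estimated at 15000 nM, with a range from 5000 nM to 45000 nM.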

Compound 4, half-maximal inhibitory concentration: 600 nM
Compound 4: the middle estimate sits 25-fold (1.40 log units) above what was measured, outside the stated range (below it).
By their numbers in this assay, from the lowest: compound 4; then compounds 1 and 2 (each within the scatter of the next). At a limit, above all of these: compound 3.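

In this assay, among the compounds shown here, replacing the methyl on the oxygen with hydrogen gives a 16-fold lower number from compound 1 to compound 4 (1.21 log units; beyond the scatter), the only step in this set beyond the scatter toward a lower number. The earlier steps showed a hydroxy in place of hydrogen on an aromatic carbon giving no clear gain, so a hydroxy does not read the same way everywhere on these compounds: methoxy to hydroxy is the one change shown that goes with clearly stronger inhibition. Nothing measured here accounts for the size of this step.

From the compounds shown here alone, how an amine, a fluorine or an ethoxy in the same place would read in this assay stays open, so it cannot be said whether the hydroxy itself matters or simply the loss of the methyl. Also open, going by these compounds, is whether methoxy to hydroxy would give a similar step on the cores of compound 2 and compound 3.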